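This account rests on a few compounds, and the source may have more. Where it says the series, first, only, none or still open, it means among the compounds named here.

Of the compounds shown here, three that share one core have been measured in a physicochemical assay for lipophilicity, read by HPLC, measured as octanol-water partition; on this read-out lower numbers stand for lower lipophilicity and higher numbers for higher lipophilicity. Compound 1 `O=C1O[C@@H](CN2CCC(c3ccc(F)cc3)CC2)CN1c1ccc(-n2cc(-c3ccccn3)cn2)c(F)c1` gives 5.78, compound 2 `O=C(OC[C@H]1CN(c2ccc(-n3cc(-c4ccccn4)cn3)c(F)c2)C(=O)O1)c1ccccc1` gives 4.21, and compound 3 `COC[C@H]1CN(c2ccc(-n3cc(-c4ccccn4)cn3)c(F)c2)C(=O)O1` gives 2.18. Compound 3 therefore stands lowest of the three, with compound 2 nearest and compound 1 furthest. Among the compounds with values here, the only measured step between neighbours, a number 2.03 log units lower from compound 2 to compound 3 (beyond the scatter), shows how strongly a single group on the core can move this read-out.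

Compound 4 `NC(=O)[C@H]1CN(c2ccc(-n3cc(-c4ccccn4)cn3)c(F)c2)C(=O)O1` differs from compound 3 in one place: carbamoyl in place of methoxymethyl on a saturated ring carbon. Within the data shown here, no measured step changes a group on this ring carbon itself, so the size of the effect is not fixed by the data; the step from compound 2 to compound 3 only shows that swaps of this kind are often well beyond the scatter. A downward step is expected, estimated as a number 1.28 log units lower from compound 3 to compound 4 (beyond the scatter). For compound 4 the value in this assay is estimated at 0.9, within a range from 0.3 to 1.6.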

Compound 4, partition coefficient: 1.59
For compound 4 the middle estimate is 0.69 log units below the measured one, within the range that was stated.
By their numbers in this assay, from the lowest: compound 4; then compound 3; then compound 2; then compound 1.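

The change of group on this saturated ring carbon moves this assay by a number 0.59 log units lower from compound 3 to compound 4 (beyond the scatter), although methoxymethyl and carbamoyl each have 3 heavy atoms, so size alone, counted in heavy atoms, does not set the read-out here. The change in the group's makeup is what remains: carbamoyl swaps a carbon for a nitrogen, adds a double bond and brings 1 hydrogen-bond donor, while the larger (benzoyloxy)methyl group gives way to carbamoyl with a number 2.62 log units lower from compound 2 to compound 4 (beyond the scatter) as a much bigger step. No measurement here explains why the number falls.

The compounds shown leave open how a carboxylic acid or an aminomethyl group on this ring carbon would read. They also leave open whether a carbamoyl group with a methyl in place of an amide hydrogen would read as low as compound 4.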